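Methyl on the aromatic arm: cytotoxicity notes

The source may report more compounds than this note shows. Statements on the series, on what has been measured and on what is new or still open speak of the compounds shown alone.

Measured in a functional assay on K562 cells (Homo sapiens) for cytotoxicity, with a stated time of 72 h; on this read-out higher numbers stand for weaker inhibition and lower numbers for stronger inhibition:
Compound 1 `CC1c2c(-c3ccncc3)c(-c3ccccc3C#N)nn2CC1(C)C` gives 77000 nM.
Compound 2 `Cc1cccc(-c2nn3c(c2-c2ccncc2)C(C)C(C)(C)C3)c1C#N` gives 92000 nM.
Compound 3 `CC1(C)Cc2c(-c3ccncc3)c(-c3ccccn3)nn2C1` gives only a limit, > 100000 nM.

Compound 2 differs from compound 1 by methyl in place of hydrogen on an aromatic carbon, and the step in this assay is a 1.2-fold higher number from compound 1 to compound 2 (0.08 log units; within the scatter). The difference between the cores of compound 1 and compound 3 is not broken down here. Compound 4 `Cc1cccc(-c2nn3c(c2-c2ccncc2)CC(C)(C)C3)n1` is not yet measured; it differs from compound 3 by methyl in place of hydrogen on an aromatic carbon, the same kind of change, though here the carbon sits on a six-membered aromatic ring with 1 nitrogen, next to the ring nitrogen, rather than on a ring of carbon only, ortho to a cyano group. Only compound 1 and compound 2 show this change measured. For compound 4 the expected step is a step that the limit leaves unreadable from compound 3 to compound 4, resting on compound 1 and compound 2 showing a 1.2-fold higher number from compound 1 to compound 2 (0.08 log units; within the scatter) and on compound 3 sitting at the limit of > 100000 nM in this assay, at which 1 of the 3 values shown sits. Compound 4 is thus estimated at 150000 nM, and a limit rather than a number is thought likely.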

Compound 4, half-maximal inhibitory concentration: > 100000 nM
Compound 4: only a limit was reported (the forecaster's own chance of this, stated with the estimate: 75%); the middle value lies beyond the limit too.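

In this assay, compound 3 and compound 4 both give only limits, so no step between them can be read: the limit of > 100000 nM in this assay, at which 2 of the 4 values shown sit.

The compounds shown leave open how far pyridin-2-yl to 6-methylpyridin-2-yl shifts cytotoxicity, and whether that change tracks the step from compound 1 to compound 2.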